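The source may hold more compounds than are shown below. What is called first, only, known or untested is meant among the compounds shown, and "the series" means these compounds.

Measured compounds in a functional assay on HCT-116 cells (Homo sapiens) for inhibition, read by MTT assay, with a stated time of 72 h; a higher number here means a weaker inhibitor, a lower number a stronger inhibitor:
- compound 1 `COc1ccc(CCCNCc2c(OC)cc(Oc3ccc(Nc4ccccc4)cc3)cc2OC)cc1` — 3230 nM
- compound 2 `COc1cc(Oc2cccc(Nc3ccccc3)c2)cc(OC)c1CNCCNC(C)=O` — 18200 nM
- compound 3 `COc1ccc([C@@H](C)NCc2c(OC)cc(Oc3cccc(Nc4ccccc4)c3)c(OC)c2OC)cc1` — 2440 nM

Compound 2 stands at the highest number of the three. Its nearest neighbour is compound 1, whose number is lower by a margin beyond the usual scatter; compound 3 lies further still, also beyond the scatter. Among the measured compounds shown here, both compound 1 and compound 3 carry a methoxyphenyl-bearing chain on the amine side of the shared core, which compound 2 does not; no step between measured compounds that differ in only one place is available, so what separates them cannot be assigned to any single change.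

Compound 4 `CCN1CCN(Cc2c(OC)cc(Oc3cccc(Nc4ccccc4)c3)cc2OC)CC1` follows from compound 2 by one change: 4-ethylpiperazin-1-yl in place of (2-acetamidoethyl)amino on a saturated chain carbon bound to an aromatic carbon. The remainder of the core of compound 2 is kept. For the measured compounds named here, no measured pair isolates this kind of change, so any expectation rests on the standing of compound 2 alone and on the open question whether the piperazine brings compound 4 nearer to compound 1 and compound 3 or leaves it where compound 2 sits.

Compound 4 is expected to give a somewhat lower number than compound 2, with the step from compound 2 to compound 4 estimated as a 2.0-fold lower number from compound 2 to compound 4 (0.31 log units; beyond the scatter), a direction held loosely. The estimate for compound 4 in this assay is 9000 nM, within 2500 nM to 30000 nM.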

Compound 4, half-maximal inhibitory concentration: > 20000 nM
Compound 4 ended at the assay's limit (the forecaster's own chance of this, stated with the estimate: 10%); middle value at least 2.2-fold (0.34 log units) away from the limit.
By their numbers in this assay, from the lowest: compounds 3 and 1 (each within the scatter of the next); then compound 2. At a limit, above all of these: compound 4.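

In this assay compound 4 stands at a limit of the assay, > 20000 nM, and this is a limit rather than a number. Among the compounds shown here, the first single-place step at this saturated chain carbon bound to an aromatic carbon reads an at least 1.0-fold higher number from compound 2 to compound 4 (0.04 log units; that floor lies within the scatter), so 4-ethylpiperazin-1-yl in place of (2-acetamidoethyl)amino gives no lower number, and only a floor is available for the size of the step: the limit of > 20000 nM in this assay, at which 1 of the 4 values shown sits. The change swaps an open chain carrying hydrogen-bond donors and a double bond outside aromatic rings for a six-membered non-aromatic ring with no hydrogen-bond donors, and this swap brings no gain in this read-out.

For the compounds shown here, the single step changes the ring, the donors and the amide carbonyl together, so it cannot show which of them matters, nor whether compound 4 lies close to compound 2 or far from it. Also open, going by these compounds, is what a simple dimethylamino group, a morpholine ring or a longer chain ending in the same acetamide would give on this carbon with the rest of the core of compound 2 kept.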